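This account rests on a few compounds, and the source may have more. Where it says the series, first, only, none or still open, it means among the compounds named here.

Three compounds share one core and differ only in the group on the saturated chain carbon bound to an amide-type nitrogen and a carbonyl carbon. In a functional assay on HeLa cells (Homo sapiens) for antiproliferative activity, read by MTT assay, with a stated time of 48 h (on this read-out higher numbers stand for weaker inhibition and lower numbers for stronger inhibition), compound 1 `CSCC[C@H](NC(=O)c1cc2ccccc2cn1)C(=O)OCc1ccccc1` gives 309 nM, compound 2 `O=C(CNC(=O)c1cc2ccccc2cn1)OCc1ccccc1` gives 195 nM, and compound 3 `NCCCC[C@H](NC(=O)c1cc2ccccc2cn1)C(=O)OCc1ccccc1` gives 196 nM. On these numbers compound 2 is separated from neither of the others by more than the scatter: there is a 1.6-fold lower number from compound 1 to compound 2 (0.20 log units; within the scatter) and a 1.0-fold higher number from compound 2 to compound 3 (0.00 log units; within the scatter). Compound 4 `CC(C)[C@H](NC(=O)c1cc2ccccc2cn1)C(=O)OCc1ccccc1` is not yet measured; it differs from compound 2 by isopropyl in place of hydrogen on a saturated chain carbon bound to an amide-type nitrogen and a carbonyl carbon. The two changes already seen at this same carbon, hydrogen entering from compound 1 and 4-aminobutyl entering toward compound 3, both stayed within the scatter, so no step beyond the scatter is expected in this assay for isopropyl either. Compound 4 is therefore expected to give about 210 nM, ranging from 100 nM to 450 nM, which means an expected step of a 1.1-fold higher number from compound 2 to compound 4 (0.03 log units; within the scatter).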

Compound 4, half-maximal inhibitory concentration: 118 nM
Estimate against measurement, compound 4: 1.8-fold (0.25 log units) above, within the range that was stated.
By their numbers in this assay, from the lowest: compounds 4, 2, 3 and 1 (each within the scatter of the next, the first and the last beyond it).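

In this assay, this carbon shows its first step beyond the scatter when isopropyl replaces 2-(methylsulfanyl)ethyl (a 2.6-fold lower number from compound 1 to compound 4 (0.42 log units; beyond the scatter)). Isopropyl does not separate from hydrogen (a 1.7-fold lower number from compound 2 to compound 4 (0.22 log units; within the scatter)) or from 4-aminobutyl (a 1.7-fold lower number from compound 3 to compound 4 (0.22 log units; within the scatter)), so the position tells apart only compound 1 and compound 4 among these compounds. No supporting data are available to explain this difference. Going by these compounds, what a carboxylic acid or a longer unbranched carbon chain would do on this carbon stays open. So does whether the step seen with isopropyl would hold for other branched carbon groups.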